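The source may hold more compounds than are shown below. What is called first, only, known or untested is meant among the compounds shown, and "the series" means these compounds.

Three compounds share one core and differ only at the ends of the molecule. Compound 1 `COc1ccc(Cn2cc(CO/N=C/c3c(-c4ccccc4)nc4c(C)cccn34)nn2)cc1` gives 100 mg/kg in a functional assay on the whole organism (strain NMRI) with Mus musculus as the target, with a stated time of 4 h; a lower number here means that less compound is needed, a higher number that more compound is needed for the effect. Compound 2 `Cc1cccn2c(/C=N/OCc3cn(Cc4ccc([N+](=O)[O-])cc4)nn3)c(-c3ccc(F)cc3)nc12` gives 40 mg/kg, and compound 3 `Cc1ccc(Cn2cc(CO/N=C/c3c(-c4ccc(F)cc4)nc4c(C)cccn34)nn2)cc1` gives 40 mg/kg. Compound 3 therefore stands level with compound 2, the two together at the lowest number of the three, while compound 1 needs a larger dose than compound 3 by a margin beyond the usual scatter.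

Compound 4 `COc1ccc(Cn2cc(CO/N=C/c3c(-c4ccc(F)cc4)nc4c(C)cccn34)nn2)cc1` is the next step from compound 3: methoxy in place of methyl on an aromatic carbon. Among the measured compounds shown here, only one measured step touches the same part of the molecule, the one from compound 2 to compound 3, where a nitro was exchanged for a methyl on the same aromatic carbon, and it gave no change at the digits printed from compound 2 to compound 3 (within the scatter). That suggests this position tolerates exchange of one small group for another without a shift in dose. Compound 1 also carries a methoxy, but it differs from compound 3 in a second place as well, so it can only hint that a methoxy there need not worsen the number. The step of no change at the digits printed from compound 3 to compound 4 (within the scatter) is therefore expected to stay within the scatter. For compound 4 the estimate is 40 mg/kg, with a range from 20 mg/kg to 100 mg/kg.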

Compound 4, minimum effective dose: 40 mg/kg
Beside the measured number, compound 4's estimate shows no gap at the digits printed; the measured number falls inside the stated range.
By their numbers in this assay, from the lowest: compounds 2, 3 and 4 (each within the scatter of the next); then compound 1.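

In this assay the exchange of 4-methylbenzyl for 4-methoxybenzyl gives no change at the digits printed from compound 3 to compound 4 (within the scatter) and the exchange of nitro for methoxy on the same aromatic carbon gives no change at the digits printed from compound 2 to compound 4 (within the scatter), so nitro, methyl and methoxy at this carbon all lie within the scatter of one another, even though methoxy, unlike methyl, counts as a hydrogen-bond acceptor. Among the compounds shown here, compound 4 also forms the first clean pair with compound 1, which differs from it in one place only, fluoro in place of hydrogen on an aromatic carbon, and this step reads a 2.5-fold lower number from compound 1 to compound 4 (0.40 log units; beyond the scatter). Among these four compounds, then, the only step beyond the scatter is the one that adds the fluoro, while the exchanges at the far end of the benzyl group leave the number where it was.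

Nothing at hand explains either result. As far as these compounds go, it stays open whether this tolerance extends to an amine, a carboxylic acid or a longer chain such as butyl on that carbon, and whether a chloro in place of the fluoro would keep the lower number.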